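Cutting the Side Chain from Compound 1

The compounds below may be only part of what the source reports. "The series", "measured", "known", "first", "only" and "open" are said of these compounds alone.

Compound 1 `Cc1n[nH]c2c1C(c1ccc(N(C)C)cc1)C(C(=O)NNC(N)=S)=C(N)N2` — 6320 nM
Compound 2 `Cc1n[nH]c2c1C(c1ccc(N(C)C)cc1)C(C(=O)N/N=C1/C(=O)Nc3ccccc31)=C(N)N2` — 57900 nM
Compound 3 `Cc1n[nH]c2c1C(c1ccc(N(C)C)cc1)C(C(=O)NNc1cc([N+](=O)[O-])ccc1[N+](=O)[O-])=C(N)N2` — 8680 nM

In a functional assay on HepG2 cells (Homo sapiens) for cytotoxicity, read by MTT assay, with a stated time of 48 h (a lower number here means a stronger inhibitor, a higher number a weaker inhibitor), compound 1 gives 6320 nM, the lowest of the three numbers shown. Compound 3 gives 8680 nM, and compound 2 gives 57900 nM. Compound 4 `Cc1n[nH]c2c1C(c1ccc(N(C)C)cc1)C=C(N)N2` differs from compound 1 in one place: a hydrogen atom in place of a group of 7 heavy atoms (2 carbon, 3 nitrogen, 1 oxygen, 1 sulfur; no ring), on a double-bonded ring carbon. For the measured compounds named here, no measured step removes this group outright; the nearest are a 9.2-fold higher number from compound 1 to compound 2 (0.96 log units; beyond the scatter) and a 1.4-fold higher number from compound 1 to compound 3 (0.14 log units; within the scatter), in which the group was altered but kept. Those two steps show that reshaping the chain costs at most a modest rise. Removing it entirely is a larger change than either, so a rise in the number beyond the scatter is expected, though without a direct precedent its size is uncertain. Compound 4 is therefore estimated at 20000 nM, between 5000 nM and 80000 nM, an expected step of a 3.2-fold higher number from compound 1 to compound 4 (0.50 log units; beyond the scatter).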

Compound 4, half-maximal inhibitory concentration: 20600 nM
Estimate against measurement, compound 4: 1.0-fold (0.01 log units) below; low and high end bracket the measured number.
By their numbers in this assay, from the lowest: compounds 1 and 3 (each within the scatter of the next); then compound 4; then compound 2.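

Putting a hydrogen atom on the double-bonded ring carbon in place of the side chain gives a 3.3-fold higher number from compound 1 to compound 4 (0.51 log units; beyond the scatter) in this assay, so the core of compound 4 still gives a measurable number with no chain at this position. Compound 2 keeps a chain there, yet at 57900 nM it stands above compound 4, so the mere presence of a chain does not lower the number. Nothing available explains this step.

As far as these compounds go, whether a carboxylic acid, a simple primary amide or a longer chain on this carbon would match compound 1 remains open.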